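The source may hold more compounds than are shown below. What is called first, only, known or untested is meant among the compounds shown, and "the series" means these compounds.

Of the compounds shown here, two have so far been tested in a functional assay on A549 cells (Homo sapiens) for antiproliferative activity, read by sulforhodamine B assay, with a stated time of 72 h; a higher number here means a weaker inhibitor of growth, a lower number a stronger inhibitor of growth. Compound 1 `COc1cc(CSc2ccc3c(C)cc(=O)oc3c2)cc(OC)c1` gives > 29200 nM in this assay, which is a limit of the assay rather than a number. Compound 2 `CCc1cc(=O)c2ccc(Sc3cccc(Cl)[n+]3[O-])cc2o1` gives > 29900 nM in this assay, also a limit. Compound 2 therefore stands at the limit of > 29900 nM in this assay, at which 1 of the 2 values shown sits. For the measured compounds named here, the only other value shown, that of compound 1, sits at the limit of > 29200 nM in this assay, at which 1 of the 2 values shown sits. Nothing among these two values separates them.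

Compound 3 `CCc1cc(=O)c2ccc(Sc3cccc(Cl)[n+]3[O-])c(C)c2o1` has not yet been measured in this assay. It differs from compound 2 in one place: methyl in place of hydrogen on an aromatic carbon. Going by the values given here, no measured pair of compounds shows what such a change does here, so there is no basis for expecting a shift in either direction. The step from compound 2 to compound 3 is expected to be a step that the limit leaves unreadable from compound 2 to compound 3, that is, nothing beyond the usual scatter. Compound 3 is estimated to give about 40000 nM in this assay, with a range from 15000 nM to 100000 nM, most likely again reported only as a limit.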

Compound 3, concentration for 50% growth inhibition: > 28700 nM
Compound 3 gave a limit, no number (the forecaster's own chance of this, stated with the estimate: 80%); the middle value does not contradict the limit.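

Compound 2 and compound 3 both gave only limits in this assay, so the effect of methyl in place of hydrogen on an aromatic carbon cannot be read. The compounds shown leave open which change, if any, would give a measurable growth-inhibition value.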